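Moving a nitro group: from compound 3 to compound 4

This account rests on a few compounds, and the source may have more. Where it says the series, first, only, none or still open, it means among the compounds named here.

- compound 1 `O=C(N/N=C/c1cccc(Br)c1)Nc1ccc(Oc2ccnc3[nH]ccc23)c(F)c1` gives 660 nM
- compound 2 `O=C(N/N=C/c1ccc(F)cc1)Nc1ccc(Oc2ccnc3[nH]ccc23)c(F)c1` gives 3880 nM
- compound 3 `O=C(N/N=C/c1cccc([N+](=O)[O-])c1)Nc1ccc(Oc2ccnc3[nH]ccc23)c(F)c1` gives 5180 nM

All three values come from a functional assay on HepG2 cells (Homo sapiens) for antiproliferative activity, read by MTT assay, with a stated time of 72 h; on this read-out higher numbers stand for weaker inhibition and lower numbers for stronger inhibition. The step of a 1.3-fold higher number from compound 2 to compound 3 (0.13 log units; within the scatter) stays within the usual scatter, so those two compounds cannot be told apart. The step of a 7.8-fold higher number from compound 1 to compound 3 (0.89 log units; beyond the scatter) goes beyond the scatter, which places compound 3 on the weaker side of this small set, level with compound 2.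

The next compound is compound 4 `O=C(N/N=C/c1ccc([N+](=O)[O-])cc1)Nc1ccc(Oc2ccnc3[nH]ccc23)c(F)c1`, which has 4-nitrophenyl in place of 3-nitrophenyl on a carbon with a double bond to nitrogen. Among the measured compounds shown here, no measured pair isolates this exact change, so the evidence is indirect. The closest guide is the step of a 1.3-fold higher number from compound 2 to compound 3 (0.13 log units; within the scatter), which swaps 4-fluorophenyl for 3-nitrophenyl and barely registers. The larger steps, a 5.9-fold higher number from compound 1 to compound 2 (0.77 log units; beyond the scatter) and a 7.8-fold higher number from compound 1 to compound 3 (0.89 log units; beyond the scatter), both start from 3-bromophenyl. They show that this ring's substituent can matter, so the range must stay wide.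

No shift beyond the scatter is expected in this assay, and the estimated step is a 1.2-fold lower number from compound 3 to compound 4 (0.06 log units; within the scatter). The expected value for compound 4 is 4500 nM, within an estimated range of 1900 nM to 11000 nM.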

Compound 4, half-maximal inhibitory concentration: 3030 nM
Compound 4: middle estimate off by 1.5-fold (0.17 log units), on the high side, within the range that was stated.
By their numbers in this assay, from the lowest: compound 1; then compounds 4, 2 and 3 (each within the scatter of the next).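

In this assay, moving the nitro group gives a 1.7-fold lower number from compound 3 to compound 4 (0.23 log units; within the scatter), so on this carbon with a double bond to nitrogen, 3-nitrophenyl and 4-nitrophenyl cannot be told apart; where the nitro group sits makes no measurable difference between these two compounds. Among the compounds shown here, exchanging fluoro for nitro on the ring gives a 1.3-fold lower number from compound 2 to compound 4 (0.11 log units; within the scatter), which also stays within the scatter, while a 4.6-fold higher number from compound 1 to compound 4 (0.66 log units; beyond the scatter) goes beyond it, so compounds 2, 3 and 4 form one level group and compound 1, with its 3-bromophenyl, is the only compound that stands apart, as the strongest of the four. Nothing measured here accounts for that separation.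

The compounds shown leave open whether compound 1 stands apart through the bromine atom itself or through where it sits on the ring, a question that a 4-bromophenyl group would help to settle. They also leave open how this position would respond to a plain phenyl ring, or to a ring carrying an amine or a carboxylic acid.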